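The source may hold more compounds than are shown below. What is called first, only, known or untested is meant among the compounds shown, and "the series" means these compounds.

Measured so far:
compound 1, `Cc1ccc2nc(NC(=O)NC(C)C)sc2c1`, gives 18500 nM in a functional assay (thoracic aorta, Rattus norvegicus, strain Wistar); on this read-out lower numbers stand for an effect already at smaller amounts and higher numbers for an effect only at larger amounts of compound;
compound 2, `CCc1ccc2nc(NC(=O)NC(C)C)sc2c1`, gives 24400 nM;
compound 3, `CC(C)NC(=O)Nc1nc2c(s1)CCCC2`, gives 47600 nM.

Compound 4, `CC(C)(C)NC(=O)Nc1nc2c(s1)CCCC2`, has not been measured yet. It differs from compound 3 by methyl in place of hydrogen on a saturated chain carbon bound to an amide-type nitrogen and two saturated chain carbons. The same kind of change has already been measured once, from compound 1 to compound 2: methyl in place of hydrogen on a saturated chain carbon bound to an aromatic carbon. The place is not the same: in compound 1 the change sits on a saturated chain carbon bound to an aromatic carbon, in compound 3 on a saturated chain carbon bound to an amide-type nitrogen and two saturated chain carbons. Compound 3 and compound 1 also rest on different cores; the difference between the two cores is not broken down here. In this assay the measured step gave a 1.3-fold higher number from compound 1 to compound 2 (0.12 log units; within the scatter). Compound 3 shows a number that is within the scatter of compound 2 and beyond the scatter of compound 1.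

For compound 4 a small step is expected because a 1.3-fold higher number from compound 1 to compound 2 (0.12 log units; within the scatter) stayed within the scatter, so the estimated step is a 1.2-fold higher number from compound 3 to compound 4 (0.06 log units; within the scatter). Compound 4 is expected to give about 55000 nM, between 25000 nM and 120000 nM.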

Compound 4, half-maximal effective concentration: 75200 nM
Beside the measured number, compound 4's estimate is 1.4-fold (0.14 log units) below it; measured number inside the range.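

In this assay, methyl in place of hydrogen gives a 1.6-fold higher number from compound 3 to compound 4 (0.20 log units; within the scatter), so the tert-butyl compound and its isopropyl partner cannot be told apart on this read-out. Set beside the earlier case, the two steps do not differ: the same change on two cores in this assay, a 1.3-fold higher number (0.12 log units; within the scatter) from compound 1 to compound 2 and a 1.6-fold higher number (0.20 log units; within the scatter) from compound 3 to compound 4, 1.2-fold (0.08 log units) apart, within the scatter of two such steps. In both pairs, then, the change left the number within the usual scatter on two different cores, but two pairs do not make a rule, and the methyl sits in a different place in each: on a saturated chain carbon bound to an aromatic carbon in one, and on a saturated chain carbon bound to an amide-type nitrogen and two saturated chain carbons in the other.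

The compounds shown therefore leave open whether the same change, made in the same place on both cores, would also give matching steps. They also leave open how a longer chain, an amine or a carboxylic acid in place of the methyl would read out on either core.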